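The compounds below may be only part of what the source reports. "The series", "measured", "known", "first", "only" and "open" are said of these compounds alone.

Working notes on the pyrrolidine series in an assay on HEK293 cells for inhibition of sodium-dependent dopamine transporter (Homo sapiens), read by scintillation counting, with a stated time of 5 min; a higher number here means a weaker inhibitor, a lower number a stronger inhibitor. Compound 1 `O=C(c1ccc2ccccc2c1)N(C1CCC1)[C@@H]1CCNC1` gives 5800 nM. Compound 2 `Cc1c(C(=O)N(CC(C)(C)C)[C@H]2CCNC2)ccc(Cl)c1Cl` reaches only the limit of > 28000 nM; one of the three values shown sits there (the limit of > 28000 nM in this assay, at which 1 of the 3 values shown sits). Compound 3 `CS(=O)(=O)N(Cc1ccc2ccccc2c1)[C@H]1CCNC1` gives 2800 nM, the lowest of the two numbers shown, with compound 1 the nearest and its number higher by a gap beyond the scatter. The step to follow is from compound 3 to compound 4 `CS(=O)(=O)N(Cc1ccc2ccccc2c1)[C@@H]1CCNC1` (the two compounds have the same atoms and bonds and differ only in configuration as drawn: 1 of 1 stereo elements differ; a stereocentre at a saturated ring carbon is drawn S in compound 3 and R in compound 4). Within the data shown here, no measured pair shows what such a change in configuration alone does here, so the direction is open; a shift in either direction, or none beyond the scatter, is expected in this assay. For compound 4 the expected value is 4000 nM, between 800 nM and 20000 nM, an expected step of a 1.4-fold higher number from compound 3 to compound 4 (0.15 log units; within the scatter).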

Compound 4, half-maximal inhibitory concentration: > 68000 nM
Compound 4 ended at the assay's limit; the forecaster's own chance of this, stated with the estimate: 15%; middle value at least 17-fold (1.23 log units) away from the limit.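

In this assay, this pair gives the series its first reading of configuration alone at the saturated ring carbon, and the change from S to R is far from neutral, with an at least 24-fold higher number from compound 3 to compound 4 (1.38 log units; beyond the scatter). For compound 4, > 68000 nM is a limit of the assay and not a number. The step can be set on this stereocentre alone: the fact that compounds 3 and 4 differ only in the configuration as drawn

This remains a single pair, so its reach across the series is open. From the compounds shown here alone, whether the same step appears with an acetyl group or a longer chain in place of the sulfonyl group of compound 3 also stays open.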